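A few compounds are considered here, and "the series" means these few. Any claim that something is new, unique, unknown or untested is made for them only; others in the source may bear on it.

Compound 1 `CC(C)N1CCN(c2ccc3c(c2)oc(=O)n3C(=O)NCCCCc2ccccc2)CC1` and compound 2 `O=C(NCCCCc1ccccc1)n1c2c(oc1=O)CCN(Cc1ccccc1)C2` were both measured in an assay on HEK293 cells for inhibition of acid ceramidase (Homo sapiens), read by fluorescence, with stated times of 10 min and 3 h; on this read-out higher numbers stand for weaker inhibition and lower numbers for stronger inhibition. In this assay compound 1 gives 211 nM, the lower of the two numbers, while compound 2 gives 436 nM. Compound 3 `CN1CCN(c2ccc3c(c2)oc(=O)n3C(=O)NCCCCc2ccccc2)CC1` is not yet measured; it differs from compound 1 only in methyl in place of isopropyl on an amine nitrogen in a ring. Among the measured compounds shown here, no measured pair shows the effect of this change here, so the step from compound 1 to compound 3 is expected to be small, a 1.4-fold higher number from compound 1 to compound 3 (0.15 log units; within the scatter), most likely within the scatter. Compound 3 is therefore estimated at 300 nM, with a range from 120 nM to 800 nM.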

Compound 3, half-maximal inhibitory concentration: 116 nM
Compound 3: middle estimate off by 2.6-fold (0.41 log units), on the high side, outside the stated range (below it).
By their numbers in this assay, from the lowest: compounds 3 and 1 (each within the scatter of the next); then compound 2.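

In this assay, the step at this position is a 1.8-fold lower number from compound 1 to compound 3 (0.26 log units; within the scatter), with methyl in place of isopropyl on an amine nitrogen in a ring. The 4-isopropylpiperazin-1-yl and 4-methylpiperazin-1-yl compounds therefore cannot be told apart on this read-out, whether the nitrogen carries the group of one carbon or the group of three. No available evidence bears on this result. The compounds shown leave open what happens at this nitrogen with a hydrogen, an acetyl group or a longer chain, and whether any such group would give a step beyond the scatter.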